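The source may report more compounds than this note shows. Statements on the series, on what has been measured and on what is new or still open speak of the compounds shown alone.

Compound 1 `Nc1ccccc1-c1cc(F)cc(-n2nnc(-c3ccccn3)n2)c1` is the strongest of the three compounds measured in an assay for binding affinity to metabotropic glutamate receptor 5 (Rattus norvegicus) (a lower number here means a stronger inhibitor, a higher number a weaker inhibitor), where compound 1 gives 7 nM. Compound 2 `Fc1cc(-c2ccccn2)cc(-n2nnc(-c3ccccn3)n2)c1` gives 95 nM in this assay, and compound 3 `Nc1ccncc1-c1cc(F)cc(-n2nnc(-c3ccccn3)n2)c1` gives 20 nM. Compound 4 `Nc1cccnc1-c1cc(F)cc(-n2nnc(-c3ccccn3)n2)c1` differs from compound 1 at one place: 3-aminopyridin-2-yl in place of 2-aminophenyl on an aromatic carbon. Within the data shown here, two measured steps bear on it. Removing the amino group and adding a ring nitrogen gave a 14-fold higher number from compound 1 to compound 2 (1.13 log units; beyond the scatter), while keeping the amino group and adding a ring nitrogen gave a 2.9-fold higher number from compound 1 to compound 3 (0.46 log units; beyond the scatter). Since compound 4 keeps the amino group, a modest weakening is expected, comparable to the step to compound 3, so for compound 4 the estimate in this assay is 20 nM, between 7 nM and 60 nM, meaning a 2.9-fold higher number from compound 1 to compound 4 (0.46 log units; beyond the scatter).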

Compound 4, inhibition constant: 31 nM
Beside the measured number, compound 4's estimate is 1.6-fold (0.19 log units) below it, and the stated range covers the measured number.
By their numbers in this assay, from the lowest: compound 1; then compounds 3 and 4 (each within the scatter of the next); then compound 2.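

With 3-aminopyridin-2-yl in place of 2-aminophenyl, this assay shows a 4.4-fold higher number from compound 1 to compound 4 (0.65 log units; beyond the scatter) as the result, so neither aminopyridine group shown matches the 2-aminophenyl group of compound 1. The two aminopyridine groups cannot be told apart here, with a 1.6-fold higher number from compound 3 to compound 4 (0.19 log units; within the scatter) as their step. The amino group is now seen alone on the same pyridine group, and adding it gives a 3.1-fold lower number from compound 2 to compound 4 (0.49 log units; beyond the scatter) as the gain. Nothing shown explains these differences. As far as these compounds go, whether a hydroxyl, methylamino or aminomethyl group could take the place of the amino group remains open.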